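The source may hold more compounds than are shown below. What is called first, only, known or untested is meant among the compounds shown, and "the series" means these compounds.

In a functional assay on MIA PaCa-2 cells (Homo sapiens) for cytotoxicity, read by fluorescence, with a stated time of 48 h (a lower number here means that less compound is needed, a higher number that more compound is needed for the effect), compound 1 (`CC(C)=CCC/C(C)=C/CC/C(C)=C/CSC[C@H](NC(=O)CCCCCN1CCCC1)C(=O)NC1CCCCC1`) gives 5600 nM and compound 2 (`CC(C)=CCC/C(C)=C/CC/C(C)=C/CSC[C@H](NC(=O)CCCCCN1CCCC1)C(=O)N1CCCCC1`) gives 12400 nM, the higher of the two numbers. Compound 3 (`CC(C)=CCC/C(C)=C/CC/C(C)=C/CSC[C@H](NC(=O)CCCCCN1CCCC1)C(=O)NC1CCCCCC1`) differs from compound 2 by cycloheptylamino in place of piperidin-1-yl on a carbonyl carbon. Within the data shown here, the only measured step bearing on this is a 2.2-fold higher number from compound 1 to compound 2 (0.35 log units; beyond the scatter), a modest one that replaces cyclohexylamino with piperidin-1-yl. Reversing that kind of change suggests a modest move toward a lower number in this assay, although no cycloheptylamino compound has yet been measured. The expected step is a 2.5-fold lower number from compound 2 to compound 3 (0.39 log units; beyond the scatter). Compound 3 is estimated at 5000 nM, with an expected range of 2000 nM to 12000 nM.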

Compound 3, half-maximal effective concentration: 6800 nM
Compound 3: the middle estimate sits 1.4-fold (0.13 log units) below what was measured; the range from low to high includes it.
By their numbers in this assay, from the lowest: compounds 1, 3 and 2 (each within the scatter of the next, the first and the last beyond it).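

In this assay, cycloheptyl in place of cyclohexyl on an amide-type nitrogen gives no readable change, with a 1.2-fold higher number from compound 1 to compound 3 (0.08 log units; within the scatter) within the scatter. Cycloheptylamino in place of piperidin-1-yl on a carbonyl carbon also stays within the scatter, with a 1.8-fold lower number from compound 2 to compound 3 (0.26 log units; within the scatter), so compound 3 cannot be separated from either neighbour. No measurement on hand accounts for these readings.

Still open, as far as these compounds go, is how a cyclopentyl or an acyclic hexyl group on that nitrogen would read. A morpholin-4-yl group on the carbonyl carbon is equally untested by these compounds.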